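Bromo to methoxy exchange tried on a second ring

A few compounds are considered here, and "the series" means these few. Any claim that something is new, unique, unknown or untested is made for them only; others in the source may bear on it.

Of the compounds shown here, three have been measured in a functional assay for inhibition, read by Griess assay, with a stated time of 150 min, tested at 1 mM; a lower number here means less inhibition, a higher number more inhibition at the concentration tested (going by the name of the read-out). Compound 1 `COc1cc(/C(Cl)=C/C=C(\C#N)C(=O)c2c[nH]c3ccc(Br)cc23)cc(OC)c1OC` gives 36.7%, the lowest of the three numbers. Compound 2 `N#C/C(=C\C=C(/Cl)c1ccc(Br)cc1)C(=O)c1c[nH]c2ccccc12` gives 76.7%, and compound 3 `COc1ccc(/C(Cl)=C/C=C(\C#N)C(=O)c2c[nH]c3ccccc23)cc1` gives 76.9%. The difference between the cores of compound 1 and compound 2 is not broken down here.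

Compound 2 and compound 3 differ in one place: methoxy in place of bromo on an aromatic carbon. That exchange produced a number 0.2 percentage points higher from compound 2 to compound 3 (within the scatter), so the two values tell no order in this assay.

Compound 4 `COc1ccc2[nH]cc(C(=O)/C(C#N)=C/C=C(\Cl)c3cc(OC)c(OC)c(OC)c3)c2c1`, still unmeasured, carries the same kind of change relative to compound 1: methoxy in place of bromo on an aromatic carbon. The place is not the same. In the measured pair the carbon sits on a six-membered aromatic ring of carbon only, para to a large group; in compound 4 it is part of a fused or bridged system of two rings, meta to a fused ring and para to a fused ring. Going by the values given here, only one earlier instance of the exchange exists, so the expectation rests on that single step.

Resting on the earlier step of a number 0.2 percentage points higher from compound 2 to compound 3 (within the scatter), the step expected in this assay is a number 3.3 percentage points higher from compound 1 to compound 4 (within the scatter). For compound 4 the expected value in this assay is 40%, within 20% to 62%.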

Compound 4, a percentage reported as inhibition, at one concentration (the size of the read-out at that concentration, not a potency): 68.3%
The estimate for compound 4 lay 28.3 percentage points below the measured number, and the stated range ends below it.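

In this assay, the exchange of bromo for methoxy on the aromatic carbon of the fused system gave a number 31.6 percentage points higher from compound 1 to compound 4 (beyond the scatter). The size of the step did not carry from one core to the other, so a step read on one core gives no safe estimate for the other in this series: the same change on two cores in this assay, a number 0.2 percentage points higher (within the scatter) from compound 2 to compound 3 and a number 31.6 percentage points higher (beyond the scatter) from compound 1 to compound 4, 31.4 percentage points apart, beyond the scatter of two such steps

The two pairs differ both in the ring that carries the exchange and in the rest of the structure, so these four compounds do not separate the place of the exchange from its molecular surroundings, and they give no general rule for the change.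

As far as these compounds go, it remains open whether the large step is particular to methoxy or would also appear with an amine or a carboxylic acid in place of the bromo on the same carbon. Also open, from the compounds shown here alone, is whether the step depends on the methoxy-bearing ring that compound 1 and compound 4 share.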